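The source may report more compounds than this note shows. Statements on the series, on what has been measured and on what is new or still open speak of the compounds shown alone.

Compound 1 `O=C(/C=C/c1cccc(O)c1)c1cccc(-n2cc(-c3ccc(Cl)cc3)[nH]c2=O)c1` and compound 2 `COc1ccc(-c2cn(-c3cccc(C(=O)/C=C/c4ccc(O)c(OC)c4)c3)c(=O)[nH]2)cc1` share one core and have been tested in a functional assay on SF-268 cells (Homo sapiens) for inhibition; a lower number here means a stronger inhibitor of growth, a higher number a weaker inhibitor of growth. Compound 1 gives 1780 nM. Compound 2 gives 3400 nM in this assay. Compound 2 thus stands at the top of the two numbers shown, but its distance to compound 1 lies within the scatter of repeated measurements of this kind, so the two cannot be told apart on these data.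

Compound 3 `COc1cc(/C=C/C(=O)c2cccc(-n3cc(-c4ccc(Cl)cc4)[nH]c3=O)c2)ccc1O` has not yet been measured in this assay. Relative to compound 2 it carries a single change: chloro in place of methoxy on an aromatic carbon. The remainder of the molecule, including the hydroxy and methoxy groups on the other side of the core, is kept from compound 2. Compound 1 already carries the 4-chlorophenyl group that enters here, and compound 1 gives 1780 nM, so the two measured values bracket the step in question. Because compound 1 gives 1780 nM and compound 2 gives 3400 nM, the step is expected to be small, toward a somewhat lower number, and not clearly beyond the scatter. On that basis compound 3 is estimated at 2400 nM in this assay, with a range of 1200 nM to 4800 nM, which would correspond to an expected step of a 1.4-fold lower number from compound 2 to compound 3 (0.15 log units; within the scatter).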

Compound 3, concentration for 50% growth inhibition: 2500 nM
The estimate for compound 3 lay 1.0-fold (0.02 log units) below the measured number, and the stated range covers the measured number.
By their numbers in this assay, from the lowest: compounds 1, 3 and 2 (each within the scatter of the next).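

Compound 1 and compound 2 differ in more than one place, so the exchange of 4-methoxyphenyl for 4-chlorophenyl could not be read from them, and compound 3 now isolates it in this assay (a 1.4-fold lower number from compound 2 to compound 3 (0.13 log units; within the scatter)). This single step lies within the scatter, so chloro and methoxy cannot be told apart at this position, para to a large group, in this series. Compound 3 also isolates the change at the other end of the molecule, 4-hydroxy-3-methoxyphenyl in place of 3-hydroxyphenyl (a 1.4-fold higher number from compound 1 to compound 3 (0.15 log units; within the scatter)), which likewise lies within the scatter, and no measurement offered here gives a reason for either result.

The compounds shown leave open whether an amine or a carboxylic acid on that aromatic carbon, in place of chloro or methoxy, would shift the number beyond the scatter. Among these compounds, it also remains open whether a longer chain at this place would do so, as chloro and methoxy are the only two groups compared here.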